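A Fluoro Substituent on the Core of Compound 1

This account rests on a few compounds, and the source may have more. Where it says the series, first, only, none or still open, it means among the compounds named here.

compound 1 `O=S(=O)(c1ccc(F)cc1)c1cnc2ccc(Cl)cc2c1-c1ccc(Cl)cc1`: 58.3%
compound 2 `N#Cc1ccc2ncc(S(=O)(=O)c3ccc(F)cc3)c(-c3ccc(Cl)cc3)c2c1`: 39.7%

In an assay on cell membranes for displacement of a labelled ligand from metabotropic glutamate receptor 5 (Rattus norvegicus), with a stated time of 60 min, tested at 1 uM (on this read-out lower numbers stand for less inhibition and higher numbers for more inhibition at the one concentration tested (going by the name of the read-out)), compound 1 gives 58.3%, the highest of the two numbers. Compound 2 gives 39.7%, and the step of a number 18.6 percentage points lower from compound 1 to compound 2 (beyond the scatter) lies beyond the scatter. Compound 3 `O=S(=O)(c1ccc(F)cc1)c1cnc2c(F)cc(Cl)cc2c1-c1ccc(Cl)cc1` differs from compound 1 by fluoro in place of hydrogen on an aromatic carbon. Within the data shown here, no measured step bears on this change: the only step known, a number 18.6 percentage points lower from compound 1 to compound 2 (beyond the scatter), concerns a different exchange on a different ring. The step of a number 3.3 percentage points lower from compound 1 to compound 3 (within the scatter) is therefore expected to remain within the scatter. Compound 3 is estimated at 55%, with a range from 35% to 75%.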

Compound 3, a percentage reported as inhibition, at one concentration (the size of the read-out at that concentration, not a potency): 19%
Compound 3: middle estimate off by 36 percentage points, on the high side; the whole stated range lies above it.
By their numbers in this assay, from the lowest: compound 3; then compound 2; then compound 1.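

In this assay, fluoro in place of hydrogen, on the aromatic carbon ortho to a fused ring and meta to the chloro group, gives a number 39.3 percentage points lower from compound 1 to compound 3 (beyond the scatter). The earlier pair showed a change only at the chloro group, whereas this step shows that the read-out also responds to a single added atom at a former hydrogen of the core. Nothing available accounts for this loss of inhibition. On these data alone, whether a methyl, a methoxy or an amine on this carbon would give a similar number remains open. Also open, as far as these compounds go, is whether fluoro here would have the same effect with nitrile in place of chloro.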